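This account rests on a few compounds, and the source may have more. Where it says the series, first, only, none or still open, it means among the compounds named here.

Three related compounds have been tested in a functional assay on K562 cells (Homo sapiens), read by MTT assay, with a stated time of 72 h; on this read-out lower numbers stand for stronger inhibition and higher numbers for weaker inhibition. Compound 1 `Cc1ncnc2c1c(I)cn2[C@@H]1O[C@H](CO)[C@@H](O)[C@H]1O` gives 17800 nM in this assay, a weak effect. Compound 2 `CSc1ncnc2c1c(-c1ccccc1)cn2[C@@H]1O[C@H](CO)[C@@H](O)[C@H]1O` reaches only the limit of this assay, reported as > 20000 nM. Compound 3 `Cc1nc(N)c2c(-c3ccccc3)cn([C@@H]3O[C@H](CO)[C@@H](O)[C@H]3O)c2n1` likewise yields only a limit, > 20000 nM. Compound 3 therefore stands where no number could be read at all, and it shares that position with compound 2, as shown by the limit of > 20000 nM in this assay, at which 2 of the 3 values shown sit.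

Compound 4 `Cc1nc(N)c2c(-c3ccco3)cn([C@@H]3O[C@H](CO)[C@@H](O)[C@H]3O)c2n1` differs from compound 3 in one place: furan-2-yl in place of phenyl on an aromatic carbon. Within the data shown here, no step between two measured compounds is available here, so the effect of such a change cannot be taken from any pair already measured.

Because compound 3 sits at the limit of > 20000 nM in this assay, at which 2 of the 3 values shown sit, compound 4 is expected to remain weak in this assay, with the change a number no higher from compound 3 to compound 4 (the limit leaves the size open) expected to amount to nothing beyond the usual scatter in either direction. The estimate for compound 4 is 20000 nM, within a range from 7000 nM to 60000 nM, and the reading may well again be only a limit.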

Compound 4, half-maximal inhibitory concentration: > 20000 nM
Compound 4 was reported as a limit (the forecaster's own chance of this, stated with the estimate: 60%); the middle value sits exactly at the limit.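

Among these compounds, compound 3 and compound 4 are both reported only as limits in this assay, so no step between them can be read. Going by these compounds, whether phenyl or furan-2-yl on this aromatic carbon gives stronger inhibition stays open, as does the true strength of either compound.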